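Urea in Place of Amide on a Shared Thiazole Core

A few compounds are considered here, and "the series" means these few. Any claim that something is new, unique, unknown or untested is made for them only; others in the source may bear on it.

The measured compounds:
Compound 1 `Fc1cccc(C#Cc2nc3c(s2)CN(C2CCOC2)CC3)c1` — in an assay on HEK293 cells for positive allosteric modulation of metabotropic glutamate receptor 5 (Homo sapiens), read by FLIPR, with a stated time of 1 h (a lower number here means that less compound is needed, a higher number that more compound is needed for the effect), compound 1 gives a value that is only a limit of the assay, > 10000 nM.
Compound 2 `O=C(C1CC(F)(F)C1)N1CCc2nc(C#Cc3cccc(F)c3)sc2C1` — in this assay compound 2 gives 2.5 nM.
Compound 3 `O=C(C1CCCC1)N1CCc2nc(C#Cc3ccccc3)sc2C1` — in this assay compound 3 gives 19 nM.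

Among the two numbers that are not limits, compound 3 has the higher one, and compound 2 stands nearest to it with a lower number. For the measured compounds named here, the only step measured in one place is an at least 4000-fold lower number from compound 1 to compound 2 (3.60 log units; beyond the scatter); it starts from a value that is a limit, (the limit of > 10000 nM in this assay, at which 1 of the 3 values shown sits), and concerns the substituent on the amine nitrogen in the ring.

Compound 4 `O=C(N1CCCC1)N1CCc2nc(C#Cc3ccccc3)sc2C1` differs from compound 3 in another place: pyrrolidin-1-yl in place of cyclopentyl on a carbonyl carbon. Going by the values given here, no measured step touches the carbonyl carbon, so the change from compound 3 to compound 4 has no direct precedent here; the one measured step says only that what sits on the amine nitrogen matters greatly, without showing how the group on the carbonyl carbon acts. With nothing pointing either way, compound 4 is expected to stay close to compound 3, and the expected step is a 1.6-fold higher number from compound 3 to compound 4 (0.20 log units; within the scatter), within the usual scatter. In this assay compound 4 is therefore estimated at 30 nM, with a plausible range from 8 nM to 120 nM.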

Compound 4, half-maximal effective concentration: 9.8 nM
Compound 4: middle estimate off by 3.1-fold (0.49 log units), on the high side; the range from low to high includes it.
By their numbers in this assay, from the lowest: compound 2; then compounds 4 and 3 (each within the scatter of the next). At a limit, above all of these: compound 1.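

In this assay, for the compounds shown here, the first measured step at the carbonyl carbon is a 1.9-fold lower number from compound 3 to compound 4 (0.29 log units; within the scatter), with pyrrolidin-1-yl in place of cyclopentyl. The earlier compounds shown here showed only that the substituent on the amine nitrogen in the ring can matter greatly; this pair shows that, with the carbonyl kept on that nitrogen, a five-membered ring of carbon only and a five-membered ring with a hetero atom, each of the same heavy-atom count, give values within the scatter of each other, so the amide and the urea cannot be told apart at this level of resolution. Nothing measured here gives a cause for this result.

The compounds shown leave open whether this tolerance extends to other groups on the carbonyl carbon, such as morpholin-4-yl, piperidin-1-yl or an open-chain dimethylamino group, and whether any of them would move the number beyond the scatter. They also leave open what the 3,3-difluorocyclobutyl group and the fluorine on the phenyl ring each contribute, as compound 2 differs from compound 3 and compound 4 in more than one place.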